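A few compounds are considered here, and "the series" means these few. Any claim that something is new, unique, unknown or untested is made for them only; others in the source may bear on it.

Compound 1 `Oc1ccccc1CNc1ccc(-c2cccc(Cl)c2)cc1` and compound 2 `Cc1cccc(-c2ccc(NCc3ccccc3O)cc2)c1` share one core, while compound 3 `Oc1ccccc1CNc1ccc(-c2ccc(Cl)cc2)nc1` and compound 4 `Cc1ccc(-c2ccc(NCc3ccccc3O)cn2)cc1` share another; the difference between the two cores is not broken down here. In a functional assay on Jurkat cells (Homo sapiens) for activation, with a stated time of 24 h (on this read-out lower numbers stand for an effect already at smaller amounts and higher numbers for an effect only at larger amounts of compound), compound 1 gives 6200 nM, and compound 2 gives 9190 nM. The change between them, (methyl in place of chloro on an aromatic carbon), made a 1.5-fold higher number from compound 1 to compound 2 (0.17 log units; within the scatter). In this assay compound 3 was reported as "not active" (no number reported), and no number was given for it. From compound 3 to compound 4 the change is methyl in place of chloro on an aromatic carbon. Within the data shown here, it is the same kind of change as the one from compound 1 to compound 2, but not the same: in the first pair the group sits meta to a large group, in the second it sits para to a large group. Since the earlier step gave a 1.5-fold higher number from compound 1 to compound 2 (0.17 log units; within the scatter), a step of similar size is expected here, so compound 4 is expected to remain near where compound 3 stands, possibly again without a reported number. Compound 4 is expected to give about 30000 nM in this assay, with an estimated range from 8000 nM to 100000 nM.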

Compound 4, half-maximal effective concentration: "not active" (no number reported)
Compound 4 has no reported number here; there is nothing to compare the estimate with.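

Compound 3 and compound 4 both stand without a number in this assay, so no step can be read for the change from 4-chlorophenyl to 4-methylphenyl. The compounds shown leave open whether swapping chloro for methyl has any measurable effect on the core of compound 3. No further measured evidence bears on this result.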